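Swapping the Benzyl Ring: Solubility Outlook for Compound 4

The compounds below may be only part of what the source reports. "The series", "measured", "known", "first", "only" and "open" are said of these compounds alone.

Compound 1 `COc1cccc(CNCCCNc2ccnc3cc(Oc4ccccc4)ccc23)c1O`: 14500 nM
Compound 2 `COc1cccc(CNCCCNc2ccnc3cc(Oc4cccc(N(C)C)c4)ccc23)c1O`: 14500 nM
Compound 3 `COc1cccc(CNCCCNc2ccnc3cc(Cc4cc(C)cc(C)c4)ccc23)c1O`: 4200 nM

All three share one core and were tested in a physicochemical assay for solubility, with a stated time of 18 h, at pH 7.4; on this read-out higher numbers stand for higher solubility and lower numbers for lower solubility. Compound 2 stands level with compound 1 (no change at the digits printed from compound 1 to compound 2 (within the scatter)), and together the two give the highest numbers of the three; compound 3 sits below them, as shown by a 3.5-fold lower number from compound 2 to compound 3 (0.54 log units; beyond the scatter) and by a 3.5-fold lower number from compound 1 to compound 3 (0.54 log units; beyond the scatter).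

Compound 4 `COc1ccc(F)cc1CNCCCNc1ccnc2cc(Oc3cccc(N(C)C)c3)ccc12` differs from compound 2 at the benzyl end of the molecule: 5-fluoro-2-methoxyphenyl in place of 2-hydroxy-3-methoxyphenyl on a saturated chain carbon bound to an amine nitrogen. Both measured steps alter the group on the aromatic carbon of the core, not the benzyl group, so neither bears directly on this change. One of them left this assay unmoved and the other gave a modest drop, which suggests changes of this scale are the norm in this set. Compound 4 is therefore expected to give about 10000 nM in this assay, with a range from 3500 nM to 30000 nM. That corresponds to an expected step of a 1.5-fold lower number from compound 2 to compound 4 (0.16 log units; within the scatter), likely within the scatter.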

Compound 4, solubility: 14500 nM
Beside the measured number, compound 4's estimate is 1.5-fold (0.16 log units) below it; the range from low to high includes it.
By their numbers in this assay, from the lowest: compound 3; then compounds 1, 2 and 4 (each within the scatter of the next).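

The earlier steps shown here all altered the group on the aromatic carbon of the core, whereas this one alters the benzyl end, and in this assay it gives no change at the digits printed from compound 2 to compound 4 (within the scatter). So, in this one pair, the read-out does not register the exchange of 2-hydroxy-3-methoxyphenyl, with 1 hydrogen-bond donor and 2 hydrogen-bond acceptors, for 5-fluoro-2-methoxyphenyl, with 0 hydrogen-bond donors and 1 hydrogen-bond acceptor. No measurement shown here explains this result.

The swap alters several features at once, so the compounds shown cannot separate the part played by the fluorine from that of the lost hydroxyl. As far as these compounds go, it also remains open whether a benzyl ring carrying an amine or a carboxylic acid would leave the number just as unmoved, and whether the same swap would do so on compound 3.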